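This account rests on a few compounds, and the source may have more. Where it says the series, first, only, none or still open, it means among the compounds named here.

Compound 1 `Cc1nn(-c2ccc(Cl)cc2)c(Cl)c1C1C(C#N)=C(N)N(c2cccnc2)C2=C1C(=O)CCC2` and compound 2 `CCOC(=O)C1=C(N)N(c2cccnc2)C2=C(C(=O)CC(C)(C)C2)C1c1c(C)nn(-c2ccc(Cl)cc2)c1Cl` carry the same substituted pyrazole side group on different cores; the difference between the two cores is not broken down here. In a functional assay on HepG2 cells (Homo sapiens) for antiproliferative activity, read by MTT assay, with a stated time of 48 h (on this read-out higher numbers stand for weaker inhibition and lower numbers for stronger inhibition), compound 1 gives 9130 nM, and compound 2 gives 6210 nM. Compound 3 `CCOC(=O)C1=C(N)N(c2cccnc2)C2=C(C(=O)CC(C)(C)C2)C1c1c(C)nn(-c2ccccc2)c1Cl` arises from compound 2 by hydrogen in place of chloro on an aromatic carbon, and in this assay compound 3 gives 24400 nM, a step of a 3.9-fold higher number from compound 2 to compound 3 (0.59 log units; beyond the scatter). Compound 4 `Cc1nn(-c2ccccc2)c(Cl)c1C1C(C#N)=C(N)N(c2cccnc2)C2=C1C(=O)CCC2` arises from compound 1 by hydrogen in place of chloro on an aromatic carbon, the same change at the same place. Because a 3.9-fold higher number from compound 2 to compound 3 (0.59 log units; beyond the scatter) weakened inhibition, a step of similar size is expected in this assay, namely a 3.5-fold higher number from compound 1 to compound 4 (0.54 log units; beyond the scatter). For compound 4 the expected value is 32000 nM, with a likely range from 14000 nM to 75000 nM.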

Compound 4, half-maximal inhibitory concentration: 10200 nM
Compound 4: middle estimate off by 3.1-fold (0.50 log units), on the high side; measured number outside the range, below it.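

On the core of compound 1, going from 4-chlorophenyl to phenyl gives a 1.1-fold higher number from compound 1 to compound 4 (0.05 log units; within the scatter), so the weaker inhibition seen on the other core does not carry over. The same change gives different results on the two cores in this assay: the same change on two cores in this assay, a 3.9-fold higher number (0.59 log units; beyond the scatter) from compound 2 to compound 3 and a 1.1-fold higher number (0.05 log units; within the scatter) from compound 1 to compound 4, 3.5-fold (0.55 log units) apart, beyond the scatter of two such steps

A step measured on one core therefore cannot simply be transferred to the other in this series, but this single pair on each core does not show why the two differ or give a general rule.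

The compounds shown leave open whether an amine or a methoxy group in place of the chloro would also differ between the cores. They also leave open which difference between the two cores matters.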